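Aryl Swap on the Amide Side Chain: Compound 2 to Compound 3

The compounds below may be only part of what the source reports. "The series", "measured", "known", "first", "only" and "open" are said of these compounds alone.

Compound 1 `CC(C)C[C@H](N)c1cc(C(F)(F)F)ccc1N1CCN(C(=O)CCc2ccccc2Cl)CC1` gives 1700 nM in an assay on HEK293 cells for displacement of a labelled ligand from Melanocortin receptor 4 (Homo sapiens); on this read-out lower numbers stand for stronger inhibition and higher numbers for weaker inhibition.
Compound 2 `CC(C)C[C@H](N)c1cc(C(F)(F)F)ccc1N1CCN(C(=O)CCc2c(Cl)cccc2Cl)CC1` gives 2600 nM in this assay.

Compound 2 holds the higher of the two numbers; its nearest neighbour is compound 1, with a 1.5-fold higher number from compound 1 to compound 2 (0.18 log units; within the scatter). Compound 3 `COc1ccc(OC)c(CCC(=O)N2CCN(c3ccc(C(F)(F)F)cc3[C@@H](N)CC(C)C)CC2)c1` differs from compound 2 by 2,5-dimethoxyphenyl in place of 2,6-dichlorophenyl on a saturated chain carbon, two bonds along the chain from a carbonyl carbon. Among the measured compounds shown here, the only measured step, a 1.5-fold higher number from compound 1 to compound 2 (0.18 log units; within the scatter), concerns one added chloro on that same ring and lies within the scatter; no measured pair shows chloro exchanged for methoxy. The step is therefore expected to be a 1.0-fold lower number from compound 2 to compound 3 (0.02 log units; within the scatter), with no direction beyond the scatter. Compound 3 is estimated at 2500 nM, within a range from 800 nM to 8000 nM.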

Compound 3, inhibition constant: 2500 nM
For compound 3 middle estimate and measured number coincide at the digits printed; the measured number falls inside the stated range.
By their numbers in this assay, from the lowest: compounds 1, 3 and 2 (each within the scatter of the next).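

In this assay, 2,5-dimethoxyphenyl in place of 2,6-dichlorophenyl gives a 1.0-fold lower number from compound 2 to compound 3 (0.02 log units; within the scatter), and in place of 2-chlorophenyl it gives a 1.5-fold higher number from compound 1 to compound 3 (0.17 log units; within the scatter). The earlier compounds shown here varied only chloro on this ring, whereas these steps show that a ring carrying methoxy groups also stays within the scatter of both chlorinated rings at this position. No available evidence accounts for this result. Going by these compounds, whether an amine or a carboxylic acid on the ring, or a longer chain before it, would move the number beyond the scatter remains open.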